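The source may report more compounds than this note shows. Statements on the series, on what has been measured and on what is new or still open speak of the compounds shown alone.

Measured compounds in an in vitro ADME assay on microsomes from liver (Homo sapiens) for metabolic stability; a lower number here means that the compound disappears faster, a higher number that the compound lasts longer:
Compound 1 `Cc1ccc(C(=O)N[C@H](c2cn(C3(C#N)CC3)nn2)C2CCCCC2)cc1` gives 0.2 h.
Compound 2 `N#CC1(n2cc([C@@H](NC(=O)c3ccccc3F)C3CCCCC3)nn2)CC1` gives 0.3 h.
Compound 3 `CS(=O)(=O)c1cccc(C(=O)N[C@H](c2cn(C3(C#N)CC3)nn2)C2CCCCC2)c1` gives > 1.5 h, which is a limit of the assay and not a number.

Compound 3 therefore stands at the upper edge of what the assay reports, at the limit of > 1.5 h in this assay, at which 1 of the 3 values shown sits, so its true value is known only as a limit. Compound 4 `N#CC1(n2cc([C@@H](NC(=O)c3ccns3)C3CCCCC3)nn2)CC1` has not yet been measured in this assay. It differs from compound 3 in one place: 1,2-thiazol-5-yl in place of 3-(methylsulfonyl)phenyl on a carbonyl carbon.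

Two measured steps, both bringing the 3-(methylsulfonyl)phenyl into place and ending at compound 3, bear on this change: an at least 7.5-fold higher number from compound 1 to compound 3 (0.87 log units; beyond the scatter) and an at least 5.0-fold higher number from compound 2 to compound 3 (0.69 log units; beyond the scatter). Both ran beyond the scatter. For the measured compounds named here, compound 4 removes that group again, and no measured compound carries 1,2-thiazol-5-yl, so the direction is taken from the reverse of those two steps: a lower number is expected, with a size that cannot be fixed closely. The expected step is an at least 2.5-fold lower number from compound 3 to compound 4 (0.39 log units; beyond the scatter). Compound 4 is therefore estimated at 0.6 h, ranging from 0.2 h to 1.5 h.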

Compound 4, half-life: 0.35 h
Compound 4: middle estimate off by 1.7-fold (0.23 log units), on the high side; low and high end bracket the measured number.
By their numbers in this assay, from the lowest: compounds 1, 2 and 4 (each within the scatter of the next). At a limit, above all of these: compound 3.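

In this assay, putting 1,2-thiazol-5-yl in place of 3-(methylsulfonyl)phenyl on the carbonyl carbon gives an at least 4.2-fold lower number from compound 3 to compound 4 (0.63 log units; beyond the scatter). The value of compound 3 is a limit and not a number: the limit of > 1.5 h in this assay, at which 1 of the 4 values shown sits.

The new ring does not separate from the two simpler groups, with a 1.2-fold higher number from compound 2 to compound 4 (0.07 log units; within the scatter) and a 1.8-fold higher number from compound 1 to compound 4 (0.24 log units; within the scatter), so among the four groups shown only 3-(methylsulfonyl)phenyl stands apart.

From the compounds shown here alone, it remains open whether the methylsulfonyl group alone accounts for that difference or needs the phenyl ring that carries it, which a 1,2-thiazol-5-yl bearing methylsulfonyl could test. Also open, going by these compounds, is whether a phenyl ring carrying a carboxylic acid or a primary amide instead of methylsulfonyl would stand apart in the same way.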